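The compounds below may be only part of what the source reports. "The series", "measured", "known", "first", "only" and "open" are said of these compounds alone.

Measured so far:
Compound 1 `O=c1c(C2N=C(c3ccccc3)SS2)coc2ccc(F)cc12`: > 100000 nM
Compound 2 `O=c1c(C2N=C(c3ccccc3)SS2)coc2ccccc12`: > 100000 nM
Compound 3 `O=c1c(C(=S)Nc2ccccc2)coc2ccccc12`: 86400 nM

All three were tested in a functional assay on OVCAR-3 cells (Homo sapiens) for inhibition, read by sulforhodamine B assay, with a stated time of 48 h; on this read-out lower numbers stand for stronger inhibition and higher numbers for weaker inhibition. Compound 2 gives > 100000 nM, which is a limit of the assay rather than a number. Compound 1 likewise gives > 100000 nM, again a limit. The change between them is fluoro in place of hydrogen on an aromatic carbon, and the step it made, a step that the two limits leave unreadable from compound 2 to compound 1, cannot be read because of the limit of > 100000 nM in this assay, at which 2 of the 3 values shown sit. Compound 3 is the only one of the three to return a number, giving 86400 nM in this assay. How the core of compound 3 differs from the core of compound 2 is not broken down here.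

Compound 4 `O=c1c(C(=S)Nc2ccccc2)coc2ccc(F)cc12` has not yet been measured. It differs from compound 3 by fluoro in place of hydrogen on an aromatic carbon, the same change that separates compound 2 from compound 1, at a place described in the same words. Since that earlier step left no readable size, the expectation for compound 4 rests mainly on the value of compound 3, 86400 nM. Among the measured compounds shown here, the one measured instance of this change, a step that the two limits leave unreadable from compound 2 to compound 1, gave no readable size in either direction. The step from compound 3 to compound 4 is therefore expected to be small, a 1.0-fold higher number from compound 3 to compound 4 (0.02 log units; within the scatter), within the usual scatter. Compound 4 is accordingly estimated at 90000 nM in this assay, expected to lie between 40000 nM and 200000 nM, with a real chance that only a limit is reported.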

Compound 4, half-maximal inhibitory concentration: > 100000 nM
Compound 4: no number, only a limit (the forecaster's own chance of this, stated with the estimate: 40%); middle value at least 1.1-fold (0.04 log units) away from the limit.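

In this assay, the new step for fluoro in place of hydrogen on an aromatic carbon is an at least 1.1-fold higher number from compound 3 to compound 4 (0.06 log units; that floor lies within the scatter), and only its floor can be given, since the fluoro compound returns a limit and not a number. Carried from one core to the other, the change therefore shows one shared outcome: neither fluoro compound, compound 1 or compound 4, returns a number in this assay, while compound 3, the hydrogen compound on the second core, is the only one of the four that does. It does not show how large the change is on either core, or whether its size carries over, as the step on the first core cannot be read and the floor of the new step lies within the scatter, so the comparison is capped by the assay: the limit of > 100000 nM in this assay, at which 3 of the 4 values shown sit.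

The compounds shown leave open whether a group other than fluoro on that aromatic carbon, such as chloro, methoxy or an amine, would return a number on either core. They also leave open whether a carboxylic acid or a longer chain placed elsewhere on the core of compound 3 would move the value away from the limit.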